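This account rests on a few compounds, and the source may have more. Where it says the series, first, only, none or still open, it means among the compounds named here.

Half-lives measured in an ADME assay on S9 fraction from liver (Mus musculus, strain ICR/CD-1) for metabolic stability, read by LC-MS, using NADPH, with a stated time of 5 min, tested at 2 uM; on this read-out higher numbers stand for a longer-lived compound and lower numbers for a shorter-lived compound:

- compound 1 `COc1ccccc1-c1ccc(S(=O)(=O)N2CCC(N3CCC(C)CC3)CC2)cc1`: 4.82 h
- compound 2 `CC1CCN(C2CCN(S(=O)(=O)c3cccc(-c4ccc5ccccc5c4)c3)CC2)CC1`: 3.4 h
- compound 3 `CC1CCN(C2CCN(S(=O)(=O)c3cccc(-c4ccc(F)cc4)c3)CC2)CC1`: 1.28 h

Of these three, compound 3 gives the lowest number, and both other compounds lie above it by more than the usual scatter. The next compound, compound 4 `CC1CCN(C2CCN(S(=O)(=O)c3cccc(-c4ccccc4)c3)CC2)CC1`, differs from compound 3 in one place: hydrogen in place of fluoro on an aromatic carbon. This is hydrogen in place of fluoro on an aromatic carbon, para to a large group, so 4-fluorophenyl becomes phenyl.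

Among the measured compounds shown here, only one measured step touches this part of the structure: a 2.7-fold lower number from compound 2 to compound 3 (0.42 log units; beyond the scatter). For the measured compounds named here, that step exchanged the whole naphthalen-2-yl for 4-fluorophenyl, a much larger change than losing one fluoro, and no measured pair isolates the fluoro alone. A small change in this assay, with no clear direction and nothing beyond the scatter, therefore seems the likeliest outcome.

The expected change is a 1.1-fold lower number from compound 3 to compound 4 (0.03 log units; within the scatter).

Compound 4 is estimated at 1.2 h, with an expected range of 0.6 h to 2.6 h.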

Compound 4, half-life: 0.517 h
Compound 4: the middle estimate sits 2.3-fold (0.37 log units) above what was measured; measured number outside the range, below it.
By their numbers in this assay, from the lowest: compound 4; then compound 3; then compounds 2 and 1 (each within the scatter of the next).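

In this assay, among the compounds shown here, this is the first pair that isolates the fluoro: a 2.5-fold lower number from compound 3 to compound 4 (0.39 log units; beyond the scatter), so hydrogen in place of fluoro on this aromatic carbon, para to a large group, gives a shorter half-life by more than the scatter. Against the same phenyl, naphthalen-2-yl shows a wider gap, a 6.6-fold lower number from compound 2 to compound 4 (0.82 log units; beyond the scatter), so the phenyl carries the lowest number among compound 2, compound 3 and compound 4, with neither of the other two going against this. Nothing available here explains why losing one fluoro moves the half-life.

As far as these compounds go, whether another group at this place, such as chloro or a nitrile, would match or exceed the number of compound 3 remains open. So does whether the fluoro step would repeat on a different core.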